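Benzoyl on the Amine: Carrying a Small Step to Compound 4

The source may hold more compounds than are shown below. What is called first, only, known or untested is meant among the compounds shown, and "the series" means these compounds.

Three compounds built on one shared core were measured in a functional assay on A375P cells (Homo sapiens) for antiproliferative activity, read by MTT assay, with a stated time of 24 h; a higher number here means a weaker inhibitor, a lower number a stronger inhibitor. Compound 1 `O=C(Nc1ccc(-n2ccc3c(NC(=O)c4ccccc4)ncnc32)cc1)c1ccc(Cl)c(C(F)(F)F)c1` gives 2300 nM in this assay. Compound 2 `Nc1ncnc2c1ccn2-c1ccc(NC(=O)c2ccc(Cl)c(C(F)(F)F)c2)cc1` gives 2900 nM. Compound 3 `Nc1ncnc2c1ccn2-c1ccc(NC(=O)c2cccc(C(F)(F)F)c2)cc1` gives 9700 nM, the highest number among the three, and its steps to both other compounds lie beyond the scatter.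

Compound 1 and compound 2 differ in one place: benzoyl in place of hydrogen on a nitrogen on an aromatic ring. This change produced a 1.3-fold lower number from compound 2 to compound 1 (0.10 log units; within the scatter). Compound 2 and compound 3 differ in another place: hydrogen in place of chloro on an aromatic carbon, a change that produced a 3.3-fold higher number from compound 2 to compound 3 (0.52 log units; beyond the scatter).

Compound 4 `O=C(Nc1ccc(-n2ccc3c(NC(=O)c4ccccc4)ncnc32)cc1)c1cccc(C(F)(F)F)c1` has not yet been measured in this assay. It differs from compound 3 by benzoyl in place of hydrogen on a nitrogen on an aromatic ring. This is the same change that separates compound 2 from compound 1; the place reads the same word for word in both pairs, a nitrogen on an aromatic ring whose other neighbours are aromatic carbon, so it is the same change and not merely the same kind. Its one known outcome, a 1.3-fold lower number from compound 2 to compound 1 (0.10 log units; within the scatter), stayed within the scatter. Because the earlier step was a 1.3-fold lower number from compound 2 to compound 1 (0.10 log units; within the scatter), the expected step from compound 3 to compound 4 is a 1.3-fold lower number from compound 3 to compound 4 (0.11 log units; within the scatter). That expectation rests on a single earlier pair only, so it is held loosely. In this assay compound 4 is expected to give about 7500 nM, with a likely range from 3000 nM to 20000 nM.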

Compound 4, half-maximal inhibitory concentration: 4700 nM
For compound 4 the middle estimate is 1.6-fold (0.20 log units) above the measured one; the range from low to high includes it.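

In this assay, benzoyl in place of hydrogen on a nitrogen on an aromatic ring gave a 2.1-fold lower number from compound 3 to compound 4 (0.31 log units; beyond the scatter), and the same change on the core of compound 2 gave a step that agrees with it: the same change on two cores in this assay, a 1.3-fold lower number (0.10 log units; within the scatter) from compound 2 to compound 1 and a 2.1-fold lower number (0.31 log units; beyond the scatter) from compound 3 to compound 4, 1.6-fold (0.21 log units) apart, within the scatter of two such steps. Hydrogen in place of chloro on an aromatic carbon also carried over from the amino compounds to the benzamido compounds, giving a 2.0-fold higher number from compound 1 to compound 4 (0.31 log units; beyond the scatter), and this step too agrees with its earlier counterpart: the same change on two cores in this assay, a 3.3-fold higher number (0.52 log units; beyond the scatter) from compound 2 to compound 3 and a 2.0-fold higher number (0.31 log units; beyond the scatter) from compound 1 to compound 4, 1.6-fold (0.21 log units) apart, within the scatter of two such steps. Together these two comparisons show that each change carried from one core to the other within the scatter of two such steps, but they rest on only one pair of cores that differ solely by chloro, and the benzoyl step lies within the scatter on one core and beyond it on the other, so they do not establish a general size for either change across the series.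

The compounds shown leave open whether an acetyl group on the same nitrogen would follow the benzoyl step. They also leave open whether fluoro or methoxy in place of chloro on that aromatic carbon would keep the steps in agreement across the two cores.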